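A few compounds are considered here, and "the series" means these few. Any claim that something is new, unique, unknown or untested is made for them only; others in the source may bear on it.

Measured so far in a physicochemical assay for solubility, read by nephelometry, measured as kinetic solubility, with a stated time of 30 min; a lower number here means a less soluble compound, a higher number a more soluble compound:
- Compound 1 `CC(C)(O)CNCCCOc1ccc([C@H]2CC[C@]3(CC2)OOC2(O3)C3CC4CC(C3)CC2C4)cc1`: > 100 ug/mL (a limit of the assay)
- Compound 2 `CC(C)(N)CCOc1ccc([C@H]2CC[C@]3(CC2)OOC2(O3)C3CC4CC(C3)CC2C4)cc1`: 50 ug/mL

Compound 1 gives > 100 ug/mL, which is a limit and not a number. Going by the values given here, compound 2, at 50 ug/mL, therefore holds the only true number in this assay, so it cannot yet be ranked against a spread of values.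

The next compound to be read is compound 3 `c1cc([C@H]2CC[C@]3(CC2)OOC2(O3)C3CC4CC(C3)CC2C4)ccc1OCC1CCNCC1`, which keeps the shared core. In it, piperidin-4-yl stands in place of 2-amino-2-methylpropyl on a saturated chain carbon bound to an oxygen on an aromatic ring: piperidin-4-yl in place of 2-amino-2-methylpropyl on a saturated chain carbon bound to an oxygen on an aromatic ring.

Among the compounds with values here, only one measured step bears on this change: an at least 2.0-fold lower number from compound 1 to compound 2 (0.30 log units; that floor lies within the scatter). That step also alters the group carried on the oxygen on the aromatic ring, but it involves neither piperidin-4-yl nor a ring, so it offers no direction for the new group. No shift beyond the scatter is therefore expected, and the estimated step is no change at the digits printed from compound 2 to compound 3 (within the scatter). For compound 3 the expected value is 50 ug/mL, with an estimated range from 20 ug/mL to 100 ug/mL.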

Compound 3, solubility: 12.5 ug/mL
Compound 3: middle estimate off by 4.0-fold (0.60 log units), on the high side, outside the stated range (below it).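

In this assay, piperidin-4-yl in place of 2-amino-2-methylpropyl on a saturated chain carbon bound to an oxygen on an aromatic ring gives a 4.0-fold lower number from compound 2 to compound 3 (0.60 log units; beyond the scatter), so this position is not indifferent to the group it carries, even though the two groups have the same count of hydrogen-bond donors and acceptors and no net charge. Set against the group with the hydroxyl, piperidin-4-yl in place of 2-((2-hydroxy-2-methylpropyl)amino)ethyl gives an at least 8.0-fold lower number from compound 1 to compound 3 (0.90 log units; beyond the scatter), the first step in this series that is shown to lie beyond the scatter. Compound 1 gives > 100 ug/mL, which is a limit and not a number, so this larger step is only a floor: the limit of > 100 ug/mL in this assay, at which 1 of the 3 values shown sits.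

Going by these compounds alone, with only one ring-bearing compound, the data leave open whether the lower number goes with the ring itself or with where its nitrogen sits, and a piperidin-3-yl or morpholine group on the same carbon would separate the two. They also leave open whether a hydroxyl on the piperidine, or a longer chain carrying it, would restore the higher number.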